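Cyclohexyl to 4-iodophenyl on the amine nitrogen

A few compounds are considered here, and "the series" means these few. Any claim that something is new, unique, unknown or untested is made for them only; others in the source may bear on it.

Compound 2 `O=C1C=C(NC2CCCCC2)C(=O)c2c1nc1n2[C@H]2OC[C@@H](O)[C@H]2OC1` carries a cyclohexyl group on its amine nitrogen. In a functional assay on MGC-803 cells (Homo sapiens) for inhibition, read by sulforhodamine B assay (on this read-out lower numbers stand for stronger inhibition and higher numbers for weaker inhibition), compound 2 gives only a limit, > 8000 nM, so no number is known for it. Two neighbours on the same core are measured: compound 1 `Cc1ccc(NC2=CC(=O)c3c(nc4n3[C@H]3OC[C@@H](O)[C@H]3OC4)C2=O)cc1C` gives 1050 nM, and compound 3 `O=C1C(NCc2ccccc2)=CC(=O)c2c1nc1n2[C@H]2OC[C@@H](O)[C@H]2OC1` gives 3490 nM. For the measured compounds named here, the one measured step, a 3.3-fold higher number from compound 1 to compound 3 (0.52 log units; beyond the scatter), does not cover the present exchange. Compound 4 `O=C1C=C(Nc2ccc(I)cc2)C(=O)c2c1nc1n2[C@H]2OC[C@@H](O)[C@H]2OC1` differs from compound 2 by 4-iodophenyl in place of cyclohexyl on an amine nitrogen. Compound 1 and compound 3, each bearing an aromatic ring, sit well away from the limit of > 8000 nM in this assay, at which 1 of the 3 values shown sits, that compound 2 reaches. Compound 4 is therefore expected to move down from that limit by an at least 5.3-fold lower number from compound 2 to compound 4 (0.72 log units; beyond the scatter), to an estimated 1500 nM, between 500 nM and 5000 nM.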

Compound 4, half-maximal inhibitory concentration: 1400 nM
The estimate for compound 4 lay 1.1-fold (0.03 log units) above the measured number; measured number inside the range.
By their numbers in this assay, from the lowest: compounds 1 and 4 (each within the scatter of the next); then compound 3. At a limit, above all of these: compound 2.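

Compound 2 gives only a limit: the limit of > 8000 nM in this assay, at which 1 of the 4 values shown sits.

Read against that limit, the exchange of cyclohexyl for 4-iodophenyl on this amine nitrogen is a step of an at least 5.7-fold lower number from compound 2 to compound 4 (0.75 log units; beyond the scatter), so only its lower bound is known. It is the first step shown in which an aromatic ring replaces a non-aromatic ring of the same size, and it turns a limit into a measured number.

The compounds shown leave open whether the ring or the iodine carries this step. A plain phenyl or a 4-chlorophenyl on the same nitrogen would separate the two.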